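A few compounds are considered here, and "the series" means these few. Any claim that something is new, unique, unknown or untested is made for them only; others in the source may bear on it.

Working notes on the oxazolone series.

Three compounds of the series have numbers in an assay on isolated protein for inhibition of acid ceramidase (Homo sapiens), read by LC-MS, with a stated time of 1 h; on this read-out higher numbers stand for weaker inhibition and lower numbers for stronger inhibition. Compound 1 `O=C(NCCCCc1ccccc1)n1c(-c2ccc(Cl)cc2)coc1=O` gives 5 nM, the lowest number of the three. Compound 2 `CC(C)CNC(=O)n1cc(-c2ccccc2)oc1=O` gives 1700 nM, the highest. Compound 3 `COc1cccc(-c2cn(C(=O)NCCCCc3ccccc3)c(=O)o2)c1` gives 341 nM and stands second highest: the nearest number is that of compound 2, higher and beyond the scatter, the furthest that of compound 1, lower and beyond the scatter.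

Compound 4 `O=C(NCCCCc1ccccc1)n1cc(-c2cnccn2)oc1=O` is not yet measured. It differs from compound 3 in one place: pyrazin-2-yl in place of 3-methoxyphenyl on an aromatic carbon. Among the measured compounds shown here, no pair of measured compounds in the set differs by this exchange alone, so the size of the step has no direct precedent here. The expectation is a step to a higher number, of moderate size, probably beyond the scatter but not assured. Compound 4 is therefore expected to give 700 nM in this assay, with a range from 150 nM to 3000 nM. The expected step is a 2.1-fold higher number from compound 3 to compound 4 (0.31 log units; beyond the scatter).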

Compound 4, half-maximal inhibitory concentration: 32 nM
For compound 4 the middle estimate is 22-fold (1.34 log units) above the measured one; the whole stated range lies above it.
By their numbers in this assay, from the lowest: compound 1; then compound 4; then compound 3; then compound 2.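

In this assay, among the compounds shown here, pyrazin-2-yl in place of 3-methoxyphenyl on the aromatic carbon next to the ring oxygen gives an 11-fold lower number from compound 3 to compound 4 (1.03 log units; beyond the scatter), the first single exchange that can be read at this position. This shows that the position accepts a six-membered aromatic ring with 2 hetero atoms, and that the 3-methoxyphenyl group is not needed to reach a number as low as that of compound 4. No measurement at hand bears on what lies behind the size of this step.

Going by these compounds, this one exchange alters the ring atoms and removes the methoxy group together, so the share of each in the step remains open. Also open, on these data alone, is whether a pyridin-2-yl or pyrimidin-2-yl ring at this place, with the rest of compound 4 kept, would hold the number.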